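The source may hold more compounds than are shown below. What is called first, only, known or untested is meant among the compounds shown, and "the series" means these compounds.

Measured compounds:
- compound 1 `O=C(COc1ccc(C(=O)/C=C/c2ccc(Cl)cc2Cl)cc1)N[C@H]1CCOC1=O`: 34400 nM
- compound 2 `CC(C)c1ccc(NCC(=O)N[C@H]2CCOC2=O)cc1`: > 64000 nM

Going by the values given here, compound 1 `O=C(COc1ccc(C(=O)/C=C/c2ccc(Cl)cc2Cl)cc1)N[C@H]1CCOC1=O` is the only member of the series with a numerical result in a functional assay on MCF7 cells (Homo sapiens) for antiproliferative activity, read by MTT assay, with a stated time of 72 h (on this read-out lower numbers stand for stronger inhibition and higher numbers for weaker inhibition), where compound 1 gives 34400 nM. Compound 2 `CC(C)c1ccc(NCC(=O)N[C@H]2CCOC2=O)cc1` returns no number in this assay; for compound 2 the result is a limit, > 64000 nM. Thus compound 1 stands as the sole measured point, and the limit of > 64000 nM in this assay, at which 1 of the 2 values shown sits, marks the other entry. Among the compounds with values here, no pair of measured compounds differing in one place is available, so no measured step size can be drawn on.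

Compound 3 `O=C(COc1ccc(C(=O)/C=C/c2ccc(Br)cc2)cc1)N[C@H]1CCOC1=O` keeps the core of compound 1 and differs by 4-bromophenyl in place of 2,4-dichlorophenyl on a double-bonded chain carbon bound to a double-bonded chain carbon. Both the leaving and the entering group are halogenated six-membered aromatic rings of carbon only, with no hydrogen-bond donors or acceptors. Within the data shown here, with no measured step to weigh, the expected change in this assay from compound 1 to compound 3 is small, not clearly beyond the usual scatter in either direction, so the estimated step is a 1.1-fold lower number from compound 1 to compound 3 (0.03 log units; within the scatter). Compound 3 is therefore expected to give about 32000 nM, within a range of 12000 nM to 85000 nM.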

Compound 3, half-maximal inhibitory concentration: > 64000 nM
Compound 3 was reported as a limit; the forecaster's own chance of this, stated with the estimate: 25%; middle value at least 2.0-fold (0.30 log units) from the limit.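

Going by these compounds alone, this position gives the first readable step, and the exchange of 2,4-dichlorophenyl for 4-bromophenyl on a double-bonded chain carbon bound to a double-bonded chain carbon does not yield a second number. In this assay compound 3 gives > 64000 nM as a limit and not as a number. The step is an at least 1.8-fold higher number from compound 1 to compound 3 (0.26 log units; that floor lies within the scatter) and so the change can be read only as a floor, which does not show a loss of activity beyond the scatter, while compound 1 remains the only numerical point and the limit now holds most of the entries: the limit of > 64000 nM in this assay, at which 2 of the 3 values shown sit.

From the compounds shown here alone, the true size of the step stays open, and so does the question of whether the swap of halogen or the loss of the second ring substituent matters here, since both change together in this one exchange. A 4-chlorophenyl group at this place would separate the two, and a phenyl ring carrying an amine or a carboxylic acid would show whether anything other than a halogenated ring is tolerated there.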